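Swapping a Tert-butyl Ester for Benzoate in a Lactone Series

A few compounds are considered here, and "the series" means these few. Any claim that something is new, unique, unknown or untested is made for them only; others in the source may bear on it.

Measured compounds:
Compound 1 `CC(=O)[C@@]1(C)C(=O)O[C@@H](OC(=O)c2ccccc2)[C@H]1C`: 1000 nM
Compound 2 `CC(=O)[C@]1(C)C(=O)O[C@@H](OC(=O)C(C)(C)C)[C@H]1C`: 4000 nM

Both compounds were tested in a functional assay on DA-3 cells for cytotoxicity against DA-3 cell line (Mus musculus), read by MTT assay; on this read-out lower numbers stand for stronger inhibition and higher numbers for weaker inhibition. Compound 1 gives 1000 nM, while compound 2 gives 4000 nM, the higher of the two numbers and a gap that lies beyond the usual scatter. For the measured compounds named here, the two compounds differ in more than one place, so no single step can be drawn between them.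

Compound 3 `CC(=O)[C@]1(C)C(=O)O[C@@H](OC(=O)c2ccccc2)[C@H]1C` has not yet been measured. It arises from compound 2 by one change, (phenyl in place of tert-butyl on a carbonyl carbon). Compound 3 thus carries the same phenyl ester as compound 1, though the two differ elsewhere in the shared core. Since compound 1 with that ester gives 1000 nM, a modest move toward a lower number is expected from compound 2 to compound 3, a 2.7-fold lower number from compound 2 to compound 3 (0.43 log units; beyond the scatter). Compound 3 is estimated at 1500 nM, with a likely range from 600 nM to 4000 nM.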

Compound 3, half-maximal inhibitory concentration: 2000 nM
The estimate for compound 3 lay 1.3-fold (0.12 log units) below the measured number; measured number inside the range.
By their numbers in this assay, from the lowest: compounds 1, 3 and 2 (each within the scatter of the next, the first and the last beyond it).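

In this assay, placing phenyl in place of tert-butyl on a carbonyl carbon gives a 2.0-fold lower number from compound 2 to compound 3 (0.30 log units; within the scatter), so in this setting the ester swap on its own does not separate the two compounds beyond the usual scatter. Changing the configuration at a saturated ring carbon gives a 2.0-fold higher number from compound 1 to compound 3 (0.30 log units; within the scatter), so this change also stays within the scatter. For the compounds shown here, this pair gives the first direct reading of that stereocentre, because a single element of configuration separates the two compounds: the fact that compounds 1 and 3 differ only in the configuration as drawn.

As far as these compounds go, it remains open whether a longer chain, or a phenyl ring carrying an amine, on this carbonyl carbon would shift the number beyond the scatter. From the compounds shown here alone, the effect of changing the other stereo elements of the shared core also remains open.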